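Replacing the (2-Phenylethenyl)carbonyl Cap with Cyclopropylsulfonyl

The compounds below may be only part of what the source reports. "The series", "measured", "known", "first", "only" and "open" are said of these compounds alone.

Compound 1, `CCN(CC)c1ccc2cc(C(=O)c3ccc(N4CCN(C(=O)CN5CCNCC5)CC4)cc3)oc2c1`: 1870 nM in a functional assay on HCT-116 cells (Homo sapiens) for cytotoxicity, read by MTT assay, with a stated time of 48 h; a lower number here means a stronger inhibitor, a higher number a weaker inhibitor
Compound 2, `CCN(CC)c1ccc2cc(C(=O)c3ccc(N4CCN(C(=O)CN5CCN(C(=O)/C=C/c6ccccc6)CC5)CC4)cc3)oc2c1`: 6810 nM

Compound 2 gives the highest of the two numbers in this assay, and the nearest measured compound is compound 1, which gives a number that is lower by a margin beyond the scatter. Compound 3, `CCN(CC)c1ccc2cc(C(=O)c3ccc(N4CCN(C(=O)CN5CCN(S(=O)(=O)C6CC6)CC5)CC4)cc3)oc2c1`, has not been measured. It differs from compound 2 in one place: cyclopropylsulfonyl in place of (2-phenylethenyl)carbonyl on an amine nitrogen in a ring.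

Among the compounds with values here, only one measured step bears on this change. It is a 3.6-fold higher number from compound 1 to compound 2 (0.56 log units; beyond the scatter), where a hydrogen on that ring nitrogen was exchanged for the (2-phenylethenyl)carbonyl group. Compound 3 carries a smaller cap on the same nitrogen rather than the bare hydrogen of compound 1, so it is expected to land between the two, perhaps closer to compound 1. The expected step is a 1.9-fold lower number from compound 2 to compound 3 (0.29 log units; within the scatter). The estimate for compound 3 in this assay is 3500 nM, within a range of 1500 nM to 8000 nM.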

Compound 3, half-maximal inhibitory concentration: > 40000 nM
Compound 3: a limit, no number; the forecaster's own chance of this, stated with the estimate: 5%; middle value at least 11-fold (1.05 log units) from the limit.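

Compound 3 ends at a limit of this assay and gives no number: the limit of > 40000 nM in this assay, at which 1 of the 3 values shown sits. Exchanging the cap on this ring nitrogen gives an at least 5.8-fold higher number from compound 2 to compound 3 (0.76 log units; beyond the scatter) in this comparison, so the two caps are not interchangeable here, even though cyclopropylsulfonyl has fewer heavy atoms than (2-phenylethenyl)carbonyl. Set against the uncapped nitrogen, the change is an at least 21-fold higher number from compound 1 to compound 3 (1.33 log units; beyond the scatter) and shows that, among these compounds, the larger cap does not give the larger rise in the number.

The sulfonyl link and the cyclopropyl ring change together in this step, so the compounds shown cannot say which of them matters. As far as these compounds go, a cyclopropylcarbonyl or a phenylsulfonyl cap on the same nitrogen would separate the two, while the true value of compound 3 remains unknown.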